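Swapping 2,6-dimethoxyphenyl for 2,4-dimethoxyphenyl on a carbonyl carbon

The source may hold more compounds than are shown below. What is called first, only, known or untested is meant among the compounds shown, and "the series" means these compounds.

Measured so far in an ADME assay on cells (Lymphocyte, Homo sapiens) for cytotoxicity, read by MTT assay, with a stated time of 48 h (a higher number here means a weaker inhibitor, a lower number a stronger inhibitor), the compounds read:
compound 1 `COC(=O)/C(=C\c1ccc(OC(=O)c2ccc(OC)cc2)cc1)Sc1ccnc2cc(Cl)ccc12` gives 63500 nM 
compound 2 `COC(=O)/C(=C\c1ccc(OC(=O)c2cc(OC)cc(OC)c2)cc1)Sc1ccnc2cc(Cl)ccc12` gives 84100 nM 
compound 3 `COC(=O)/C(=C\c1ccc(OC(=O)c2c(OC)cccc2OC)cc1)Sc1ccnc2cc(Cl)ccc12` gives > 100000 nM as a limit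

Compound 3 stands at > 100000 nM in this assay and this is a limit of the assay, not a number. Among the compounds with values here, it is the only one of the three compounds in that position (the limit of > 100000 nM in this assay, at which 1 of the 3 values shown sits). The step now followed leads to compound 4 (`COC(=O)/C(=C\c1ccc(OC(=O)c2ccc(OC)cc2OC)cc1)Sc1ccnc2cc(Cl)ccc12`), which keeps the shared core and carries 2,4-dimethoxyphenyl in place of 2,6-dimethoxyphenyl on a carbonyl carbon.

Three measured steps change the same group. They are a 1.3-fold higher number from compound 1 to compound 2 (0.12 log units; within the scatter) and an at least 1.5-fold higher number from compound 1 to compound 3 (0.19 log units; that floor lies within the scatter) and an at least 1.1-fold higher number from compound 2 to compound 3 (0.07 log units; that floor lies within the scatter) and all of them lie within the scatter, the last two being only floors set by the limit. On the evidence of a 1.3-fold higher number from compound 1 to compound 2 (0.12 log units; within the scatter) no step beyond the scatter is expected in this assay for this change, in either direction. The estimated change is an at least 1.2-fold lower number from compound 3 to compound 4 (0.09 log units; that floor lies within the scatter) and it is expected to be small, and compound 4 may also end at the limit. For compound 4 the estimate is 80000 nM with 45000 nM to 140000 nM as the expected range.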

Compound 4, half-maximal inhibitory concentration: 41600 nM
Compound 4: the middle estimate sits 1.9-fold (0.28 log units) above what was measured, and the stated range ends above it.
By their numbers in this assay, from the lowest: compounds 4, 1 and 2 (each within the scatter of the next, the first and the last beyond it). At a limit, above all of these: compound 3.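

In this assay, none of the earlier changes to this group gave a step that could be read as beyond the scatter, but the 2,4-dimethoxyphenyl group does: an at least 2.4-fold lower number from compound 3 to compound 4 (0.38 log units; beyond the scatter), and a 2.0-fold lower number from compound 2 to compound 4 (0.31 log units; beyond the scatter). With the same atoms in the group on the carbonyl carbon, the 2,4-dimethoxyphenyl, 3,5-dimethoxyphenyl and 2,6-dimethoxyphenyl forms are thus not interchangeable in this assay, although methoxy in place of hydrogen on an aromatic carbon of compound 1 stays within the scatter: a 1.5-fold lower number from compound 1 to compound 4 (0.18 log units; within the scatter). The value of compound 3 is a limit of the assay and not a number, and its step is only a floor: the limit of > 100000 nM in this assay, at which 1 of the 4 values shown sits.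

Going by these compounds, how far compound 3 lies past that limit, and so the full size of its step, remains open. Also open, on these data alone, is whether a hydroxyl group, an ethoxy group or an amine in place of methoxy on this phenyl ring would give a step beyond the scatter in this assay.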